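Urea to Benzamide on a Shared Core

The compounds below may be only part of what the source reports. "The series", "measured", "known", "first", "only" and "open" are said of these compounds alone.

Compound 1 `O=C(Nc1cccc(-n2cc(-c3ccncc3)c(-c3ccc(Cl)c(O)c3)n2)c1)Nc1ccc(Cl)c(Cl)c1`, compound 2 `COc1cc(-c2nn(-c3cccc(NC(=O)c4ccc(Cl)c(C(F)(F)F)c4)c3)cc2-c2ccncc2)ccc1Cl`, compound 3 `COc1cc(-c2nn(-c3cccc(NC(=O)Nc4cccc(C(F)(F)F)c4)c3)cc2-c2ccncc2)ccc1Cl` and the not yet measured compound 4 `COc1cc(-c2nn(-c3cccc(NC(=O)c4ccccc4)c3)cc2-c2ccncc2)ccc1Cl` share one core, and three of them have been tested in a functional assay on TK-10 cells (Homo sapiens) for inhibition, read by sulforhodamine B assay, with a stated time of 48 h; a higher number here means a weaker inhibitor of growth, a lower number a stronger inhibitor of growth. For compound 1 the result is only a limit of the assay, > 32500 nM. For compound 2 the result is likewise a limit, > 32500 nM. Among the measured compounds shown here, compound 3 gives 19000 nM, the only real number among the three, the other two sitting at the limit of > 32500 nM in this assay, at which 2 of the 3 values shown sit. For the measured compounds named here, the one measured step, an at least 1.7-fold lower number from compound 2 to compound 3 (0.23 log units; that floor lies within the scatter), is thus itself only a floor. The change now followed is phenyl in place of (3-(trifluoromethyl)phenyl)amino on a carbonyl carbon, so the amino link and the trifluoromethyl leave together. The expected step is a 1.6-fold higher number from compound 3 to compound 4 (0.20 log units; within the scatter). For compound 4 the estimated value is 30000 nM, between 12000 nM and 70000 nM.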

Compound 4, concentration for total growth inhibition: > 100000 nM
Compound 4: no number, only a limit; the forecaster's own chance of this, stated with the estimate: 55%; at least 3.3-fold (0.52 log units) between middle value and limit.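

In this assay, phenyl in place of (3-(trifluoromethyl)phenyl)amino on the carbonyl carbon gives an at least 5.2-fold higher number from compound 3 to compound 4 (0.72 log units; beyond the scatter), the first step shown here that lies beyond the scatter. That step is only a floor, as compound 4 carries a limit of the assay: the limit of > 100000 nM in this assay, at which 1 of the 4 values shown sits. The step between compound 2 and compound 4 cannot be read, as both values are limits.

As far as these compounds go, the amino link and the trifluoromethyl leave together, so which of them matters remains open. Also open, from the compounds shown here alone, is how a nitrile or a carboxylic acid in place of the trifluoromethyl would behave.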